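The source may hold more compounds than are shown below. What is called first, only, known or untested is meant among the compounds shown, and "the series" means these compounds.

Measured compounds:
compound 1 `Nc1ccc2cccc(OCC3CCOC3)c2n1`, giving 115 nM in an assay on cells with melanin-concentrating hormone receptor 1 (Homo sapiens) as the target, read by radioligand binding; a lower number here means a stronger inhibitor, a higher number a weaker inhibitor.
compound 3 `CC1CCCC(Oc2cccc3ccc(N)nc23)C1`, giving 640 nM in this assay.
compound 2 `CC(CC(C)(C)C)Oc1cccc2ccc(N3CCCCC3)nc12`, for which this assay returns only > 2000 nM, a limit of the assay rather than a number.

Compound 1 holds the lowest of the two numbers in this assay; compound 3 sits higher by a gap that is beyond the usual scatter of the assay. Compound 2 sits at the limit of > 2000 nM in this assay, at which 1 of the 3 values shown sits, and so contributes no number to compare. For the measured compounds named here, no pair of measured compounds differs in a single place, so no measured step is available for sizing the change now in question.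

Compound 4 `Nc1ccc2cccc(OCCC3CC3)c2n1` differs from compound 1 by cyclopropylmethyl in place of oxolan-3-yl on a saturated chain carbon bound to an oxygen on an aromatic ring. The ring that leaves carries one hydrogen-bond acceptor and the ring that enters carries none; nothing measured here shows what that exchange does. The step from compound 1 to compound 4 in this assay is expected to be a 1.9-fold higher number from compound 1 to compound 4 (0.28 log units; within the scatter), a modest weakening that may not clear the scatter. Compound 4 is therefore expected to give about 220 nM in this assay, with a range from 60 nM to 800 nM.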

Compound 4, half-maximal inhibitory concentration: 492 nM
Compound 4: middle estimate off by 2.2-fold (0.35 log units), on the low side; the range from low to high includes it.
By their numbers in this assay, from the lowest: compound 1; then compounds 4 and 3 (each within the scatter of the next). At a limit, above all of these: compound 2.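

In this assay, for the compounds shown here, cyclopropylmethyl in place of oxolan-3-yl on a saturated chain carbon bound to an oxygen on an aromatic ring gives a 4.3-fold higher number from compound 1 to compound 4 (0.63 log units; beyond the scatter), the first measured step at this position. The position is therefore sensitive to this exchange: the weaker number goes with the entering ring, which carries no hydrogen-bond acceptor, though this single pair also changes ring size and cannot separate the two differences. Nothing measured here accounts for the size of the step.

Open, on these data alone, is whether the ring oxygen of oxolan-3-yl matters in itself, a question that cyclopentyl on the same position would address. Also open, as far as these compounds go, is whether a ring is needed at all, or whether an open chain such as 2-methoxyethyl serves equally well.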